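Working notes on a sodium/hydrogen exchanger inhibitor series

The source may report more compounds than this note shows. Statements on the series, on what has been measured and on what is new or still open speak of the compounds shown alone.

Measured so far in a functional assay for inhibition of sodium/hydrogen exchanger (Oryctolagus cuniculus); on this read-out lower numbers stand for stronger inhibition and higher numbers for weaker inhibition:
- compound 1 `Cc1cc(Cl)c(S(C)(=O)=O)cc1C(=O)N=C(N)N`: 25 nM
- compound 2 `CCc1cc(C)c(C(=O)N=C(N)N)cc1S(C)(=O)=O`: 4.8 nM
- compound 3 `Cc1cc(-c2ccccc2)c(S(C)(=O)=O)cc1C(=O)N=C(N)N`: 19 nM

Compound 3 stands second highest of the three numbers in this assay; its nearest neighbour is compound 1, with the gap a 1.3-fold lower number from compound 1 to compound 3 (0.12 log units; within the scatter), while the other step that reaches it is a 4.0-fold higher number from compound 2 to compound 3 (0.60 log units; beyond the scatter). The next compound, compound 4 `Cc1cc(OC(C)C)c(S(C)(=O)=O)cc1C(=O)N=C(N)N`, differs from compound 3 by isopropoxy in place of phenyl on an aromatic carbon.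

Going by the values given here, two measured steps bear on this change. Replacing chloro by ethyl gave a 5.2-fold lower number from compound 1 to compound 2 (0.72 log units; beyond the scatter), and replacing ethyl by phenyl gave a 4.0-fold higher number from compound 2 to compound 3 (0.60 log units; beyond the scatter). A small alkyl-type group at this position therefore went with the lowest number seen, whereas chloro and phenyl gave higher numbers that lie within the scatter of each other. Isopropoxy is closer in size to ethyl than to phenyl, so a modest lowering is expected, though the oxygen-bearing group has no direct precedent here and the expectation is loose.

For compound 4 the expected step is a 1.9-fold lower number from compound 3 to compound 4 (0.28 log units; within the scatter), giving an estimated 10 nM in this assay, in the range 3 nM to 30 nM.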

Compound 4, half-maximal inhibitory concentration: 19 nM
Compound 4: middle estimate off by 1.9-fold (0.28 log units), on the low side; low and high end bracket the measured number.
By their numbers in this assay, from the lowest: compound 2; then compounds 3, 4 and 1 (each within the scatter of the next).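

In this assay the step from phenyl to isopropoxy shows no change at the digits printed from compound 3 to compound 4 (within the scatter), so removing the aromatic ring and introducing a hydrogen-bond acceptor leaves the number in place at this position. Isopropoxy also falls with chloro, with a 1.3-fold lower number from compound 1 to compound 4 (0.12 log units; within the scatter), but it does not match ethyl, with a 4.0-fold higher number from compound 2 to compound 4 (0.60 log units; beyond the scatter), which leaves compound 2 as the only one of the four set apart from the rest. No measurement at hand accounts for the gap between ethyl and isopropoxy.

Ethyl is the only alkyl group shown at this position, so it remains open whether a lower number extends to propyl or a longer chain. Methoxy would test whether isopropoxy's result holds for a smaller group attached through oxygen, and an amine would test a different attached atom.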